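Chloro in Place of Methoxy on the Benzoyl Ring

A few compounds are considered here, and "the series" means these few. Any claim that something is new, unique, unknown or untested is made for them only; others in the source may bear on it.

Compound 1, `COc1cc(-c2nnc3n2NC(c2ccco2)C(C(=O)c2ccc(Cl)cc2)S3)cc(OC)c1OC`: in a functional assay on MCF7 cells (Homo sapiens) for cytotoxicity, read by MTT assay, with a stated time of 48 h (a lower number here means a stronger inhibitor, a higher number a weaker inhibitor), compound 1 gives > 100000 nM, which is a limit of the assay and not a number.
Compound 2, `COc1cc(-c2nnc3n2NC(c2cccs2)C(C(=O)c2ccc(F)cc2)S3)cc(OC)c1OC`: in this assay compound 2 gives 43700 nM.
Compound 3, `COc1ccc(C(=O)C2Sc3nnc(-c4cc(OC)c(OC)c(OC)c4)n3NC2c2cccs2)cc1`: in this assay compound 3 gives 49500 nM.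

The three measured compounds share one core and differ in the substituent on the benzoyl ring and in the five-membered ring attached to the core. Among the measured compounds shown here, compound 3 sits alongside compound 2: the one measured step, a 1.1-fold higher number from compound 2 to compound 3 (0.05 log units; within the scatter), lies within the scatter, so the two numbers cannot be ordered. For the measured compounds named here, compound 1 is the only compound here that carries chloro, but it also differs from compound 3 in a second place, so its limit cannot be read as a step.

Compound 4 is `COc1cc(-c2nnc3n2NC(c2cccs2)C(C(=O)c2ccc(Cl)cc2)S3)cc(OC)c1OC`. It arises from compound 3 by chloro in place of methoxy on an aromatic carbon. Going by the values given here, the only measured step at this position, fluoro to methoxy, changed nothing beyond the scatter. Compound 1, which also carries chloro, gave only a limit. A modest weakening is therefore expected for compound 4, a 1.4-fold higher number from compound 3 to compound 4 (0.15 log units; within the scatter), with a fair chance that this assay again reports only a limit. In this assay compound 4 is estimated at 70000 nM, between 30000 nM and 200000 nM.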

Compound 4, half-maximal inhibitory concentration: 42800 nM
Compound 4: the middle estimate sits 1.6-fold (0.21 log units) above what was measured, and the stated range covers the measured number.
By their numbers in this assay, from the lowest: compounds 4, 2 and 3 (each within the scatter of the next). At a limit, above all of these: compound 1.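

Compound 4 completes a set of three groups on the benzoyl ring, all with thiophen-2-yl in the other place, and in this assay this position shows no readable response: chloro in place of methoxy gives a 1.2-fold lower number from compound 3 to compound 4 (0.06 log units; within the scatter), and chloro in place of fluoro gives a 1.0-fold lower number from compound 2 to compound 4 (0.01 log units; within the scatter). Chloro therefore does not set these compounds apart, and the only step here beyond the scatter comes from the other place, where thiophen-2-yl replaces furan-2-yl: an at least 2.3-fold lower number from compound 1 to compound 4 (0.36 log units; beyond the scatter). The value of compound 1 is a limit of the assay and not a number, so that step has no exact size: the limit of > 100000 nM in this assay, at which 1 of the 4 values shown sits.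

The compounds shown leave open whether a group of a different kind on this ring, such as an amine or a carboxylic acid, would move the number beyond the scatter. From the compounds shown here alone, the ring exchange also rests on a single pair carrying chloro, so it remains open whether the same exchange would give a similar step with methoxy or fluoro on the benzoyl ring.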